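From Urea to Amide on a Shared Core

This account rests on a few compounds, and the source may have more. Where it says the series, first, only, none or still open, it means among the compounds named here.

Compound 1 `COc1cc(Cl)cc(-c2nn(-c3cccc(NC(=O)Nc4cccc(C(F)(F)F)c4)c3)cc2-c2ccncc2)c1` and compound 2 `COc1cc(Cl)cc(-c2nn(-c3cccc(NC(=O)c4cc(C(F)(F)F)cc(C(F)(F)F)c4)c3)cc2-c2ccncc2)c1` share one core and differ in the group on the carbonyl carbon. In a functional assay on HCT-116 cells (Homo sapiens) for inhibition, read by sulforhodamine B assay, with a stated time of 48 h, tested at 10 uM (on this read-out higher numbers stand for a weaker effect at the one concentration tested and lower numbers for a stronger effect), compound 1 gives 5.07%, the lowest of the two numbers shown, while compound 2 gives 35.2%, a value beyond the scatter of compound 1. Compound 3 `COc1cc(Cl)cc(-c2nn(-c3cccc(NC(=O)c4ccc(Cl)c(Cl)c4)c3)cc2-c2ccncc2)c1` has not yet been measured. It differs from compound 1 by 3,4-dichlorophenyl in place of (3-(trifluoromethyl)phenyl)amino on a carbonyl carbon, so compound 3 carries an amide rather than a urea, as compound 2 does. A step in this assay toward a weaker effect is expected, beyond the scatter, because compound 2 gives 35.2% in the same assay with the same kind of carbonyl link. The expected step of a number 19.9 percentage points higher from compound 1 to compound 3 (beyond the scatter) rests on this single comparison. For compound 3 the estimate in this assay is 25%, within a range from 7% to 55%.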

Compound 3, a percentage reported as activity, at one concentration (the size of the read-out at that concentration, not a potency): 44.1%
Compound 3: the middle estimate sits 19.1 percentage points below what was measured, and the stated range covers the measured number.
By their numbers in this assay, from the lowest: compound 1; then compounds 2 and 3 (each within the scatter of the next).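

In this assay, putting 3,4-dichlorophenyl in place of (3-(trifluoromethyl)phenyl)amino on a carbonyl carbon is a large step: a number 39 percentage points higher from compound 1 to compound 3 (beyond the scatter) on the shared core. Compound 2 and compound 3 carry differently substituted phenyl rings on the amide carbonyl, yet their numbers lie within the scatter of each other, so both amides read alike here while the urea, compound 1, stands apart from compound 3. Nothing measured here explains why this change weakens the effect.

As far as these compounds go, the change removes the amino nitrogen and alters the ring substituents at once, so the share of each in the step stays unknown. A (3,4-dichlorophenyl)amino group on the same carbonyl carbon, or a 3-(trifluoromethyl)phenyl group directly on it, would separate the two.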